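Sulfonyl aryl swaps on a benzoxazole series at the assay limit

The source may report more compounds than this note shows. Statements on the series, on what has been measured and on what is new or still open speak of the compounds shown alone.

Compound 1, `O=S(=O)(Nc1ccc(-c2nc3ccccc3o2)cc1)c1ccccc1O`: > 100000 nM
Compound 2, `Cc1cccc(S(=O)(=O)Nc2ccc(-c3nc4ccccc4o3)cc2)c1`: > 100000 nM
Compound 3, `COc1ccccc1S(=O)(=O)Nc1ccc(-c2nc3ccccc3o2)cc1`: > 100000 nM

The three measured compounds share one core and differ only in the aryl group on the sulfonyl sulfur. In an assay on cells for inhibition of HSP60/HSP10 (Homo sapiens), with a stated time of 60 min (a lower number here means a stronger inhibitor, a higher number a weaker inhibitor), compound 1 gives a value that is a limit of the assay, > 100000 nM. Compound 2 likewise gives a limit in this assay, > 100000 nM. Compound 3 stands at the same limit in this assay, > 100000 nM, so its position on the numbers is known only as a limit and not as a value.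

The steps a step that the two limits leave unreadable from compound 1 to compound 2, a step that the two limits leave unreadable from compound 1 to compound 3 and a step that the two limits leave unreadable from compound 2 to compound 3 give no readable size, because of the limit of > 100000 nM in this assay, at which 3 of the 3 values shown sit.

Compound 4, `Cc1ccc(S(=O)(=O)Nc2ccc(-c3nc4ccccc4o3)cc2)cc1`, differs from compound 3 by 4-methylphenyl in place of 2-methoxyphenyl on a sulfonyl sulfur. Going by the values given here, every measured step bears on it only in that none could be read, and no step out of the limit has been seen among compounds 1, 2 and 3. Compound 4 is therefore expected to stay at the limit, with an estimate of 150000 nM in this assay, ranging from 50000 nM to 500000 nM. The expected step that the limit leaves unreadable from compound 3 to compound 4 is thus none beyond the scatter.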

Compound 4, half-maximal inhibitory concentration: > 100000 nM
Compound 4: no number, only a limit; the forecaster's own chance of this, stated with the estimate: 85%; the middle value lies beyond the limit too.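

In this assay, going by these compounds alone, compound 4 also gives only a limit, so no step linking it to compound 1, compound 2 or compound 3 can be read: the limit of > 100000 nM in this assay, at which 4 of the 4 values shown sit. The compounds shown leave open whether any aryl group on the sulfonyl sulfur of the shared core gives a readable value in this assay, and how far these four compounds lie from one another.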